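The source may report more compounds than this note shows. Statements on the series, on what has been measured and on what is new or still open speak of the compounds shown alone.

In an ADME assay on Huh-7 cells (Homo sapiens) for cytotoxicity, read by colorimetric assay (on this read-out higher numbers stand for lower toxicity in this test and lower numbers for higher toxicity in this test), compound 2 `C#Cc1cccc(-c2cc(O[C@H]3C[C@H]4C(=O)N(C)CCCC/C=C/[C@@H]5C[C@@]5(C(=O)NS(=O)(=O)C5(C)CC5)NC(=O)N4C3)c3ccc(OC)c(C)c3n2)c1` gives 75000 nM, the higher of the two numbers in hand; compound 1 `COc1ccc2c(O[C@H]3C[C@H]4C(=O)N(C)CCCC/C=C/[C@@H]5C[C@@]5(C(=O)NS(=O)(=O)C5(C)CC5)NC(=O)N4C3)cc(-n3cc(C(C)C)cn3)nc2c1C` gives 9610 nM. For the measured compounds named here, the one measured step, a 7.8-fold higher number from compound 1 to compound 2 (0.89 log units; beyond the scatter), concerns a different exchange and bears only loosely on the change to compound 3 `C#Cc1csc(-c2cc(O[C@H]3C[C@H]4C(=O)N(C)CCCC/C=C/[C@@H]5C[C@@]5(C(=O)NS(=O)(=O)C5(C)CC5)NC(=O)N4C3)c3ccc(OC)c(C)c3n2)n1`, which carries 4-ethynyl-1,3-thiazol-2-yl in place of 3-ethynylphenyl on an aromatic carbon. Going by the values given here, no measured step matches this exchange of one aromatic group for another, so the number is expected to stay near that of compound 2 or shift within the usual scatter, in either direction. Compound 3 is therefore estimated at 45000 nM, with a range from 15000 nM to 100000 nM. That estimate means an expected step of a 1.7-fold lower number from compound 2 to compound 3 (0.22 log units; within the scatter).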

Compound 3, half-maximal cytotoxic concentration: 75000 nM
Beside the measured number, compound 3's estimate is 1.7-fold (0.22 log units) below it; measured number inside the range.
By their numbers in this assay, from the lowest: compound 1; then compounds 2 and 3 (each within the scatter of the next).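

In this assay, no change at the digits printed from compound 2 to compound 3 (within the scatter) shows that at this position, next to the ring nitrogen, 4-ethynyl-1,3-thiazol-2-yl and 3-ethynylphenyl read alike, even though the ring changes in size and in hetero atoms. With a 7.8-fold higher number from compound 1 to compound 3 (0.89 log units; beyond the scatter), the thiazole repeats the separation from 4-isopropyl-1H-pyrazol-1-yl that the phenyl had already shown. Nothing given here accounts for either step.

As far as these compounds go, whether the ethynyl group contributes to that separation remains open, since both higher compounds carry it. From the compounds shown here alone, how a plain phenyl, or an aryl ring bearing an amine or a carboxylic acid, would read here also remains open.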